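Replacing the aryl group on a fast-cleared compound

This account rests on a few compounds, and the source may have more. Where it says the series, first, only, none or still open, it means among the compounds named here.

Among the measured compounds shown here, in an ADME assay on microsomes from liver (Mus musculus) for metabolic stability (on this read-out higher numbers stand for fast clearance and lower numbers for slow clearance), compound 1 (`CCS(=O)(=O)Nc1ccc(Oc2ccc(C(F)(F)F)cc2)c(-c2cn(C)c(=O)c3[nH]ccc23)c1`) gives 2830 mL/min/kg, the higher of the two numbers so far. Compound 2 (`Cn1cc(-c2cc(NS(C)(=O)=O)ccc2Oc2ccccc2C(F)(F)F)c2cc[nH]c2c1=O`) gives 1350 mL/min/kg, lower by slightly more than the usual scatter. Compound 3 (`CCS(=O)(=O)Nc1ccc(OC2CCN(C)CC2)c(-c2cn(C)c(=O)c3[nH]ccc23)c1`) follows from compound 1 with the change (1-methylpiperidin-4-yl in place of 4-(trifluoromethyl)phenyl on an oxygen on an aromatic ring), which puts 1-methylpiperidin-4-yl in place of 4-(trifluoromethyl)phenyl on an oxygen on an aromatic ring. For the measured compounds named here, no measured pair tests this change, so what follows is judgement only. A clear fall in clearance, beyond the scatter, is expected, with an estimated step of a 9.4-fold lower number from compound 1 to compound 3 (0.97 log units; beyond the scatter). For compound 3 the estimated clearance is 300 mL/min/kg, with an expected range of 80 mL/min/kg to 1000 mL/min/kg.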

Compound 3, clearance: < 85 mL/min/kg
Compound 3 gave a limit, no number (the forecaster's own chance of this, stated with the estimate: 5%); middle value at least 3.5-fold (0.54 log units) away from the limit.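

Placing 1-methylpiperidin-4-yl in place of 4-(trifluoromethyl)phenyl on this oxygen gives an at least 33-fold lower number from compound 1 to compound 3 (1.52 log units; beyond the scatter) in this assay and marks this position as a strong lever on clearance. Compound 1 and compound 2 both carry a trifluoromethyl-substituted phenyl here, so only compound 3 shows the effect of leaving that aryl type. From the compounds shown here alone, compound 3 gives a limit, not a number, so the full size of the step stays unknown: the limit of < 85 mL/min/kg in this assay, at which 1 of the 3 values shown sits.

The change swaps the ring type and adds a ring nitrogen at once, so their contributions remain unseparated. A cyclohexyl group or an unsubstituted piperidin-4-yl on the same oxygen would help to separate them.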